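This account rests on a few compounds, and the source may have more. Where it says the series, first, only, none or still open, it means among the compounds named here.

Compound 1 `COc1ccc2c(c1)C(n1ccccc1=O)=CC(C)(C)O2`: 6.55
Compound 2 `COc1ccc(C(=O)c2ccc3c(c2)C(n2ccccc2=O)=CC(C)(C)O3)cc1`: 6.15

Both numbers come from a functional assay (aorta) with Rattus norvegicus as the target; a higher number here means a more potent compound, by a factor of ten per unit of this negative logarithm, a lower number a less potent compound. For the measured compounds named here, compound 1 stands highest of the two, and the only other measured compound, compound 2, lies lower by a margin beyond the usual scatter of this assay. Going by the values given here, no step between measured compounds that differ in a single place has been worked out, so the change studied here rests on one comparison only.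

Compound 3 `CC1(C)C=C(n2ccccc2=O)c2cc(C(=O)c3cccs3)ccc2O1` has not yet been measured. Its structure differs from compound 1 in a single spot: (thiophen-2-yl)carbonyl in place of methoxy on an aromatic carbon. The small methoxy group is thus traded for a much larger ketone carrying a five-membered aromatic ring with one hetero atom.

The measured pair gives one hint about what a large group in this place does. Compound 2, which also replaces the methoxy with a bulky ketone, gives 6.15, a lower number than compound 1. The step of a number 0.35 log units lower from compound 1 to compound 3 (beyond the scatter) is therefore expected to be downward, and of a size beyond the scatter. Compound 3 is expected at 6.2, with a likely range from 5.7 to 6.7.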

Compound 3, logarithm of the reciprocal of the active concentration, log(1/C): 6.4
Compound 3: the middle estimate sits 0.20 log units below what was measured; the range from low to high includes it.
By their numbers in this assay, from the lowest: compounds 2, 3 and 1 (each within the scatter of the next, the first and the last beyond it).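

In this assay, (thiophen-2-yl)carbonyl in place of methoxy on this aromatic carbon gives a number 0.15 log units lower from compound 1 to compound 3 (within the scatter), so a group with many more heavy atoms and a five-membered aromatic ring leaves a number that cannot be told apart from that of compound 1. Thiophen-2-yl in place of 4-methoxyphenyl on the carbonyl carbon gives a number 0.25 log units higher from compound 2 to compound 3 (within the scatter), so the two ketones cannot be told apart either, although compound 2 and compound 1 do lie beyond the scatter of each other. Compound 3 thus bridges the two by small steps, and nothing measured here bears on the reason for these results.

Both large groups shown carry a carbonyl on the aromatic carbon, so a phenyl ring attached directly, without that carbonyl, would be needed to separate the part played by the ring from that of the ketone. As far as these compounds go, it also remains open how this position responds to quite different groups, such as an amine, a carboxylic acid or a longer alkyl chain.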